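Cytotoxicity notes: amide in place of aryltriazole

This account rests on a few compounds, and the source may have more. Where it says the series, first, only, none or still open, it means among the compounds named here.

Compound 3 `COc1ccc(C[C@H]2COC(=O)[C@@H]2Cc2ccc(OCc3cn(-c4ccc(Br)cc4)nn3)c(OC)c2)cc1OC` gives 128000 nM in an ADME assay on HeLa cells (Homo sapiens) for cytotoxicity, read by MTT assay; a lower number here means a stronger inhibitor, a higher number a weaker inhibitor. Compound 2 `COc1ccc(C[C@H]2COC(=O)[C@@H]2Cc2ccc(OC(=O)CCC(=O)N3CCCCC3)c(OC)c2)cc1OC` gives 128000 nM in this assay, the same number at the digits recorded, so neither can be set above the other. Compound 1 `COc1ccc(C[C@H]2COC(=O)[C@@H]2Cc2ccc(OCc3cn(-c4cccc(Cl)c4)nn3)c(OC)c2)cc1OC` gives 493000 nM in this assay, the highest of the three, and the step of a 3.9-fold lower number from compound 1 to compound 3 (0.59 log units; beyond the scatter) lies beyond the scatter.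

Compound 4 `CCN(CC)C(=O)COc1ccc(C[C@H]2C(=O)OC[C@@H]2Cc2ccc(OC)c(OC)c2)cc1OC` is not yet measured. The change is diethylcarbamoyl in place of 1-(4-bromophenyl)-1H-1,2,3-triazol-4-yl on a saturated chain carbon bound to an oxygen on an aromatic ring. For the measured compounds named here, no measured step bears directly on it: the only step available, from compound 1 to compound 3, alters the aromatic ring carried on the triazole, not the triazole itself. Compound 2 shows that an amide-bearing group on the same phenolic oxygen gives a number equal to compound 3 at the digits recorded. Going by the values given here, with that single comparison and no direct step, no change beyond the scatter is expected, so a 1.2-fold higher number from compound 3 to compound 4 (0.07 log units; within the scatter) is the estimated step. Compound 4 is expected to give 150000 nM in this assay, with a range from 50000 nM to 450000 nM.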

Compound 4, half-maximal inhibitory concentration: 188000 nM
Compound 4: the middle estimate sits 1.3-fold (0.10 log units) below what was measured; the range from low to high includes it.
By their numbers in this assay, from the lowest: compounds 2, 3 and 4 (each within the scatter of the next); then compound 1.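

In this assay the aryltriazole is not required at this position: on a saturated chain carbon bound to an oxygen on an aromatic ring, diethylcarbamoyl, which has no ring, gives a 1.5-fold higher number from compound 3 to compound 4 (0.17 log units; within the scatter) against 1-(4-bromophenyl)-1H-1,2,3-triazol-4-yl. The two amide-bearing groups also cannot be told apart, since a 1.5-fold higher number from compound 2 to compound 4 (0.17 log units; within the scatter) separates the ring-free group of 8 heavy atoms from the group of 12 heavy atoms with its six-membered non-aromatic ring. Only the comparison with 1-(3-chlorophenyl)-1H-1,2,3-triazol-4-yl clears the scatter, with a 2.6-fold lower number from compound 1 to compound 4 (0.42 log units; beyond the scatter), leaving compound 1 apart from the other three. Nothing available explains these steps.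

As far as these compounds go, whether an amine, a carboxylic acid or a longer chain on the same oxygen would stay in this range remains open. So does whether the gap between the two triazoles follows the halogen or its place on the phenyl ring.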